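Cytotoxicity of Catechol Vinyl Sulfone Amides: Nitro for Methyl

This account rests on a few compounds, and the source may have more. Where it says the series, first, only, none or still open, it means among the compounds named here.

Measured compounds and values:
compound 1, `COc1ccc(C(=O)Nc2ccc(CCS(=O)(=O)/C=C/c3ccc(O)c(O)c3)cc2)cc1`, > 1000000 nM
compound 2, `O=C(Nc1ccc(CCS(=O)(=O)/C=C/c2ccc(O)c(O)c2)cc1)c1cc(F)cc(F)c1`, 414000 nM
compound 3, `Cc1ccc(C(=O)Nc2ccc(CCS(=O)(=O)/C=C/c3ccc(O)c(O)c3)cc2)cc1`, 168000 nM

In an ADME assay on TZM cells (Homo sapiens) for cytotoxicity, read by CCK-8 assay, with a stated time of 2 days (on this read-out lower numbers stand for higher toxicity in this test and higher numbers for lower toxicity in this test), compound 3 gives the lowest of the two numbers reported. Compound 2 sits above it, as a 2.5-fold lower number from compound 2 to compound 3 (0.39 log units; beyond the scatter) shows. Compound 1 returns only a limit of the assay, (the limit of > 1000000 nM in this assay, at which 1 of the 3 values shown sits), and not a number.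

Compound 4, `O=C(Nc1ccc(CCS(=O)(=O)/C=C/c2ccc(O)c(O)c2)cc1)c1ccc([N+](=O)[O-])cc1`, has not yet been measured. It differs from compound 3 in one place: nitro in place of methyl on an aromatic carbon.

Among the measured compounds shown here, two measured steps bear on this change, since both alter the same aromatic ring attached to the carbonyl. The step of an at least 5.9-fold lower number from compound 1 to compound 3 (0.77 log units; beyond the scatter) and the step of a 2.5-fold lower number from compound 2 to compound 3 (0.39 log units; beyond the scatter) both move the number downward toward compound 3, so every substitution seen so far on this ring shifts the read-out beyond the scatter. For the measured compounds named here, replacing methyl with nitro is therefore expected to move the number again, most likely back upward, by an amount comparable to the steps observed, though the direction rests on only two comparisons.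

Compound 4 is estimated to give 280000 nM, within 110000 nM to 750000 nM, which would mean an expected step of a 1.7-fold higher number from compound 3 to compound 4 (0.22 log units; within the scatter).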

Compound 4, half-maximal cytotoxic concentration: 483000 nM
The estimate for compound 4 lay 1.7-fold (0.24 log units) below the measured number; low and high end bracket the measured number.
By their numbers in this assay, from the lowest: compound 3; then compounds 2 and 4 (each within the scatter of the next). At a limit, above all of these: compound 1.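

Putting nitro in place of methyl on this aromatic carbon, para to a large group, changes the read-out in this assay: there is a 2.9-fold higher number from compound 3 to compound 4 (0.46 log units; beyond the scatter), so the low number of compound 3 does not carry over to this replacement. Among the compounds shown here, that leaves compound 3 as the only one of the measured compounds set apart at the low end, whereas the 4-nitrophenyl and 3,5-difluorophenyl groups on the carbonyl cannot be separated, with a 1.2-fold higher number from compound 2 to compound 4 (0.07 log units; within the scatter), and the methoxy compound stays apart from the nitro compound, with an at least 2.0-fold lower number from compound 1 to compound 4 (0.31 log units; beyond the scatter). Compound 1 remains a limit of the assay and not a number, so this last step has no upper end: the limit of > 1000000 nM in this assay, at which 1 of the 4 values shown sits.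

On these data alone, whether the low number belongs to methyl alone remains open, since an ethyl, a chlorine, an amine or a carboxylic acid on the same aromatic carbon would be needed to tell whether it is specific to that group. It also remains open whether the nitro result holds at other places on this ring, and nothing shown explains why methyl and nitro differ here.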